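This account rests on a few compounds, and the source may have more. Where it says the series, first, only, none or still open, it means among the compounds named here.

Two compounds in the series have numbers in a functional assay on HeLa cells (Homo sapiens) for inhibition, read by MTT assay; a higher number here means a weaker inhibitor, a lower number a stronger inhibitor. Compound 1 `O=C(CBr)Nc1ccc(C(=O)/C=C/c2cn(Cc3ccc(Br)cc3)nn2)cc1` gives 7950 nM; compound 2 `CCCCCCCCn1cc(/C=C/C(=O)c2ccc(NC(=O)CN3CCN(c4ccccc4)CC3)cc2)nn1` gives 33800 nM and stands highest of the two, set apart from compound 1 by a gap beyond the scatter. The two differ in more than one place, so the gap is not assigned to a single change.

Compound 3 `O=C(CN1CCN(c2ccccc2)CC1)Nc1ccc(C(=O)/C=C/c2cn(Cc3ccc(Br)cc3)nn2)cc1` is still to be measured. Relative to compound 2 it carries the change (4-bromophenyl in place of heptyl on a saturated chain carbon bound to an aromatic nitrogen), which brings in the same 4-bromobenzyl that compound 1 carries, while keeping the amide side of compound 2. Compound 1 with that group gives 7950 nM, the lower of the two numbers, so a move toward lower numbers is plausible, but the uncertainty is wide. The expected step from compound 2 to compound 3 is a 2.3-fold lower number from compound 2 to compound 3 (0.35 log units; beyond the scatter). Compound 3 is estimated at 15000 nM, within 4000 nM to 60000 nM.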

Compound 3, half-maximal inhibitory concentration: 79700 nM
For compound 3 the middle estimate is 5.3-fold (0.73 log units) below the measured one; measured number above the stated range.
By their numbers in this assay, from the lowest: compound 1; then compound 2; then compound 3.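

In this assay, with the 4-phenylpiperazin-1-yl amide side held fixed, 4-bromophenyl in place of heptyl on a saturated chain carbon bound to an aromatic nitrogen gives a 2.4-fold higher number from compound 2 to compound 3 (0.37 log units; beyond the scatter), so the 4-bromobenzyl group does not lower the number on this amide side. With 4-bromobenzyl held fixed, 4-phenylpiperazin-1-yl in place of bromo on a saturated chain carbon bound to a carbonyl carbon gives a 10-fold higher number from compound 1 to compound 3 (1.00 log units; beyond the scatter), which shows that the low number of compound 1 does not follow from 4-bromobenzyl alone. No measurement at hand accounts for either step.

Still open, from the compounds shown here alone, is whether octyl paired with the bromo amide side would follow the same direction. Also open, going by these compounds, is how an unsubstituted benzyl or a shorter chain such as butyl would read on either amide side.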